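A chloro-to-methyl swap on the benzyl ring

This account rests on a few compounds, and the source may have more. Where it says the series, first, only, none or still open, it means among the compounds named here.

Of the compounds shown here, two have been measured in a functional assay on PC-3 cells (Homo sapiens) for cytotoxicity, read by sulforhodamine B assay; a higher number here means a weaker inhibitor of growth, a lower number a stronger inhibitor of growth. Compound 1 `COc1cccc(OC)c1OCCNCCOc1ccccc1OCc1ccccc1` gives 26900 nM, and compound 2 `COc1cccc(OC)c1OCCNCCOc1ccccc1OCc1ccc(Cl)cc1` gives 2400 nM. Among the measured compounds shown here, the single measured step, an 11-fold lower number from compound 1 to compound 2 (1.05 log units; beyond the scatter), is the only guide available, and it leaves compound 2 with the lowest number of the two, with compound 1 as its nearest neighbour.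

Compound 3 `COc1cccc(OC)c1OCCNCCOc1ccccc1OCc1cccc(C)c1` differs from compound 2 by 3-methylphenyl in place of 4-chlorophenyl on a saturated chain carbon bound to an oxygen on an aromatic ring. For the measured compounds named here, no measured step covers this exact change; the one step known shows only that removing the chlorine from the benzyl ring raised the number sharply from compound 2 back to compound 1. Since compound 3 also loses the chlorine but gains a 3-methylphenyl in its place, a rise in the number beyond the scatter, though smaller than the step to compound 1, is expected. Compound 3 is therefore estimated at 6000 nM in this assay, within 2000 nM to 18000 nM, a step of a 2.5-fold higher number from compound 2 to compound 3 (0.40 log units; beyond the scatter).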

Compound 3, concentration for 50% growth inhibition: 12000 nM
For compound 3 the middle estimate is 2.0-fold (0.30 log units) below the measured one, within the range that was stated.
By their numbers in this assay, from the lowest: compound 2; then compound 3; then compound 1.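

In this assay, among the compounds shown here, chlorine is not the only group on the benzyl ring that gives a lower number, since a methyl group also does so relative to the unsubstituted ring (a 2.2-fold lower number from compound 1 to compound 3 (0.35 log units; beyond the scatter)). That gain is smaller than the one seen with chlorine (an 11-fold lower number from compound 1 to compound 2 (1.05 log units; beyond the scatter)), and exchanging 4-chlorophenyl for 3-methylphenyl costs growth-inhibiting strength (a 5.0-fold higher number from compound 2 to compound 3 (0.70 log units; beyond the scatter)), so the two substituted rings are not interchangeable here. No supporting measurements are available to explain this difference.

The exchange alters both the group and its place on the ring, so the compounds shown leave open how much of the loss belongs to each. A 3-chlorophenyl or a 4-methylphenyl group on the same chain carbon would separate the two.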